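The source may hold more compounds than are shown below. What is called first, only, known or untested is meant among the compounds shown, and "the series" means these compounds.

Working notes on the series. The shared core of compound 1 `CCOc1ccccc1NCn1nc(-c2ccc3c(c2)OCCO3)oc1=S` is kept throughout; compound 2 `Fc1ccccc1NCn1nc(-c2ccc3c(c2)OCCO3)oc1=S` and compound 3 `S=c1oc(-c2ccc3c(c2)OCCO3)nn1CNc1ccc(Cl)cc1Cl` vary only the aryl group on the amine nitrogen. In a functional assay, with a stated time of 6 min (a higher number here means a weaker inhibitor, a lower number a stronger inhibitor), compound 1 gives 5280 nM, compound 2 gives 6390 nM and compound 3 gives 8710 nM; the steps of a 1.2-fold higher number from compound 1 to compound 2 (0.08 log units; within the scatter), a 1.6-fold higher number from compound 1 to compound 3 (0.22 log units; within the scatter) and a 1.4-fold higher number from compound 2 to compound 3 (0.13 log units; within the scatter) all lie within the scatter, so the three sit together. Compound 4 `O=[N+]([O-])c1cccc(NCn2nc(-c3ccc4c(c3)OCCO4)oc2=S)c1` is unmeasured; the change from compound 3 is 3-nitrophenyl in place of 2,4-dichlorophenyl on an amine nitrogen. The steps from compound 1 and compound 2 to compound 3 both swap the aryl on the amine nitrogen and stayed within the scatter, so no step beyond the scatter is expected here. Compound 4 is expected to give 7500 nM (range 3500 nM to 16000 nM), a step of a 1.2-fold lower number from compound 3 to compound 4 (0.06 log units; within the scatter).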

Compound 4, half-maximal inhibitory concentration: 8870 nM
For compound 4 the middle estimate is 1.2-fold (0.07 log units) below the measured one; the range from low to high includes it.
By their numbers in this assay, from the lowest: compounds 1, 2, 3 and 4 (each within the scatter of the next).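

With 3-nitrophenyl in place of 2,4-dichlorophenyl on the amine nitrogen, this assay does not separate the two: a 1.0-fold higher number from compound 3 to compound 4 (0.01 log units; within the scatter). The other two steps, a 1.4-fold higher number from compound 2 to compound 4 (0.14 log units; within the scatter) and a 1.7-fold higher number from compound 1 to compound 4 (0.23 log units; within the scatter), also stay within the scatter, so a nitro-bearing aryl group, with its 2 hydrogen-bond acceptors, sits together with the ethoxy, fluoro and dichloro aryl groups. No measurement at hand bears on why these aryl groups fall together. Open, from the compounds shown here alone, is whether a carboxylic acid on this aryl ring, or a cyclohexyl group replacing it, would give a step beyond the scatter.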